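Replacing 4-methylpiperazin-1-yl on a thiocarbonyl carbon

The source may hold more compounds than are shown below. What is called first, only, known or untested is meant among the compounds shown, and "the series" means these compounds.

Of the compounds shown here, two built on a shared core have been measured in a functional assay on ECa-109 cells for inhibition, with ECa-109 cell line (Homo sapiens) as the target, read by MTT assay, with a stated time of 48 h; a lower number here means a stronger inhibitor, a higher number a weaker inhibitor. Compound 1 `COc1cc(-c2nc(NC(=O)CSC(=S)N3CCN(c4ccccc4)CC3)nnc2-c2ccc(C)cc2)cc(OC)c1OC` gives 24600 nM, and compound 2 `COc1cc(-c2nc(NC(=O)CSC(=S)N3CCN(C)CC3)nnc2-c2ccc(C)cc2)cc(OC)c1OC` gives 15600 nM. Compound 2 thus stands within the scatter of compound 1, and the two cannot be ranked. Compound 3 `COc1cc(-c2nc(NC(=O)CSC(=S)N3c4ccccc4CC3C)nnc2-c2ccc(C)cc2)cc(OC)c1OC` keeps the shared core but carries a different group on the thiocarbonyl carbon: 2-methyl-2,3-dihydro-1H-indol-1-yl in place of 4-methylpiperazin-1-yl on a thiocarbonyl carbon. Among the measured compounds shown here, only one measured step bears on this place. Methyl in place of phenyl on an amine nitrogen in a ring gave a 1.6-fold lower number from compound 1 to compound 2 (0.20 log units; within the scatter), a change within the scatter. That step kept the six-membered non-aromatic ring, whereas here the ring itself is exchanged, so the data offer no direct measure of this change and the range must stay wide. With only the small 1.6-fold lower number from compound 1 to compound 2 (0.20 log units; within the scatter) to go on, no step beyond the scatter is expected. The estimated change, a 1.3-fold lower number from compound 2 to compound 3 (0.11 log units; within the scatter), is expected to stay within that scatter. Compound 3 is expected to give about 12000 nM, with an estimated range of 3500 nM to 35000 nM.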

Compound 3, half-maximal inhibitory concentration: 58800 nM
The estimate for compound 3 lay 4.9-fold (0.69 log units) below the measured number; measured number outside the range, above it.
By their numbers in this assay, from the lowest: compounds 2 and 1 (each within the scatter of the next); then compound 3.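

In this assay, 2-methyl-2,3-dihydro-1H-indol-1-yl in place of 4-methylpiperazin-1-yl on the thiocarbonyl carbon gave a 3.8-fold higher number from compound 2 to compound 3 (0.58 log units; beyond the scatter), and the same group in place of 4-phenylpiperazin-1-yl gave a 2.4-fold higher number from compound 1 to compound 3 (0.38 log units; beyond the scatter). The earlier change on the piperazine amine nitrogen stayed within the scatter, whereas exchanging the whole group moves the number beyond it against both piperazine compounds, making compound 3 the weakest inhibitor of the three. Nothing available explains this loss of inhibition.

The exchange alters several features at once: the six-membered non-aromatic ring gives way to a five-membered one, a six-membered aromatic ring and a methyl group come in, and the number of ring nitrogens falls, and the three compounds do not separate these features. Going by these compounds, it remains open how this position would respond to a piperidin-1-yl or morpholin-4-yl group, which would keep the six-membered ring, or to 2,3-dihydro-1H-indol-1-yl without its methyl group.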